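Series notes: from compound 2 to compound 4

The source may hold more compounds than are shown below. What is called first, only, known or untested is meant among the compounds shown, and "the series" means these compounds.

Values in an ADME assay on HeLa cells (Homo sapiens) for cytotoxicity, read by MTT assay (on this read-out higher numbers stand for weaker inhibition and lower numbers for stronger inhibition), so far
- compound 1 `COC(=O)[C@@H]1CCCN1C(=O)CCC(=O)Oc1ccc(C[C@H]2C(=O)OC[C@@H]2Cc2ccc(OC)c(OC)c2)cc1OC` gives 145000 nM
- compound 2 `COc1ccc(C[C@H]2COC(=O)[C@@H]2Cc2ccc(OCc3cn(Cc4ccc(Cl)cc4)nn3)c(OC)c2)cc1OC` gives 242000 nM
- compound 3 `COc1ccc(C[C@H]2COC(=O)[C@@H]2Cc2ccc(OC(=O)CCC(=O)N3CCCC3)c(OC)c2)cc1OC` gives 201000 nM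

All three values lie within the scatter of one another, so compound 2 stands level with compound 1 and compound 3. Compound 4 `COc1ccc(C[C@H]2COC(=O)[C@@H]2Cc2ccc(OCc3cn(-c4ccc(C)cc4)nn3)c(OC)c2)cc1OC` carries 4-methylphenyl in place of 4-chlorobenzyl on an aromatic nitrogen. Going by the values given here, no step at that nitrogen has been measured. Among the compounds with values here, the one measured step, hydrogen in place of methoxycarbonyl on a saturated ring carbon, is a 1.4-fold higher number from compound 1 to compound 3 (0.14 log units; within the scatter) and lies elsewhere on the molecule. It offers only weak guidance, and no change beyond the scatter is expected. In this assay the expected step is a 1.3-fold lower number from compound 2 to compound 4 (0.11 log units; within the scatter) and no firm direction is implied. For compound 4 the estimate is 190000 nM with an expected range of 100000 nM to 350000 nM in this series.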

Compound 4, half-maximal inhibitory concentration: >= 600000 nM
Compound 4 gave a limit, no number (the forecaster's own chance of this, stated with the estimate: 15%); middle value at least 3.1-fold (0.49 log units) from the limit.
By their numbers in this assay, from the lowest: compounds 1, 3 and 2 (each within the scatter of the next). At a limit, above all of these: compound 4.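

In this assay, going by these compounds alone, 4-methylphenyl in place of 4-chlorobenzyl on an aromatic nitrogen gives an at least 2.4-fold higher number from compound 2 to compound 4 (0.39 log units; beyond the scatter), so the group at this position can move the read-out beyond the scatter, which the earlier compounds did not show. Compound 4 gives a limit, not a number: the limit of >= 600000 nM in this assay, at which 1 of the 4 values shown sits.

The change removes the chlorine and the benzyl carbon together, so the compounds shown do not separate the two. From the compounds shown here alone, how benzyl, 4-chlorophenyl, a longer chain such as 2-phenylethyl or an amine at this nitrogen would read remains open.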